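Longer alkyl chain on the shared core: compound 4

The source may report more compounds than this note shows. Statements on the series, on what has been measured and on what is new or still open speak of the compounds shown alone.

Three analogues share one core and differ only in the group on an aromatic carbon of the five-membered ring. Compound 1 `O=c1cc(Cn2cc(CCCCl)nn2)c2ccc(O)cc2o1` carries a 3-chloropropyl group; in a functional assay on SW-620 cells (Homo sapiens) for inhibition, read by MTT assay, with a stated time of 72 h (a lower number here means a stronger inhibitor, a higher number a weaker inhibitor), compound 1 gives 59800 nM. Compound 2 `CC(O)c1cn(Cc2cc(=O)oc3cc(O)ccc23)nn1` carries a 1-hydroxyethyl group. In this assay compound 2 reaches only a limit of the assay, > 100000 nM. Compound 3 `CC(C)(C)c1cn(Cc2cc(=O)oc3cc(O)ccc23)nn1` carries a tert-butyl group. In this assay compound 3 likewise reaches only a limit of the assay, > 100000 nM. Compound 3 thus stands at the limit of > 100000 nM in this assay, at which 2 of the 3 values shown sit. The steps that lead to it are an at least 1.6-fold higher number from compound 1 to compound 3 (0.22 log units; that floor lies within the scatter) and a step that the two limits leave unreadable from compound 2 to compound 3.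

Compound 4 `CCCCCCCCc1cn(Cc2cc(=O)oc3cc(O)ccc23)nn1` is the next member: octyl in place of tert-butyl on an aromatic carbon. Going by the values given here, no measured step exchanges one plain alkyl group for another, so the step from compound 3 to compound 4 has no direct precedent; the two limits and the single number for compound 1 give nothing that points to a move beyond the scatter. The expected step is a number no higher from compound 3 to compound 4 (the limit leaves the size open) in this assay. Compound 4 is therefore estimated at 100000 nM, with a range from 40000 nM to 300000 nM, and a limit rather than a number remains the likelier outcome.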

Compound 4, half-maximal inhibitory concentration: 50900 nM
Beside the measured number, compound 4's estimate is 2.0-fold (0.29 log units) above it; measured number inside the range.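

In this assay compound 4 gives 50900 nM, a number rather than a limit, so a plain alkyl group at this position can give a readable value; the steps to it are an at least 1.9-fold lower number from compound 3 to compound 4 (0.29 log units; that floor lies within the scatter) and an at least 1.9-fold lower number from compound 2 to compound 4 (0.29 log units; that floor lies within the scatter). Octyl and 3-chloropropyl give no separable result here, with a 1.2-fold lower number from compound 1 to compound 4 (0.07 log units; within the scatter). Only compound 1 and compound 4, the two carrying these chains, give numbers so far, while compound 2 and compound 3 remain at a limit: the limit of > 100000 nM in this assay, at which 2 of the 4 values shown sit.

On these data alone, whether a longer chain such as dodecyl moves the number beyond the scatter stays open. So does the effect of an octyl chain ending in an amine or a carboxylic acid.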